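This account rests on a few compounds, and the source may have more. Where it says the series, first, only, none or still open, it means among the compounds named here.

The study concerns a single series built on the shared core of compound 1 `CCN(CC)C(=O)Nc1ncc(C(Oc2ccc3cc(Br)ccc3c2)c2ccc(Cl)cc2)s1`, whose members differ in the group attached to the amino nitrogen of that core. In an ADME assay on HepG2 2.2.15 cells (Homo sapiens) for cytotoxicity (a higher number here means that more compound is tolerated, a lower number that less compound is tolerated), compound 1 is recorded as "not toxic" (no number reported). Compound 2 `O=S(=O)(Nc1ncc(C(Oc2ccc3cc(Br)ccc3c2)c2ccc(Cl)cc2)s1)c1cccs1` carries a thiophenesulfonyl group where compound 1 carries a urea; in this assay compound 2 is likewise recorded as "not toxic" (no number reported). For the measured compounds named here, compound 3 `CCc1ccc(S(=O)(=O)Nc2ncc(C(Oc3ccc4cc(Br)ccc4c3)c3ccc(Cl)cc3)s2)cc1` is the only member with a numerical entry. In this assay compound 3 reaches > 50000 nM, which is a limit of the assay and not a number. Compound 3 therefore stands at the tolerated end of what the assay can resolve, the one quantitative point in the set (the limit of > 50000 nM in this assay, at which 1 of the 3 values shown sits).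

Compound 4 `O=S(=O)(Nc1ncc(C(Oc2ccc3cc(Br)ccc3c2)c2ccc(Cl)cc2)s1)c1ccc(Cl)cc1` has not yet been tested. It differs from compound 3 in one place: chloro in place of ethyl on an aromatic carbon, para to a large group. Going by the values given here, no step between two measured compounds exists for comparison, so the size of this change in this assay cannot be read from the data. The step is expected to be a number no higher from compound 3 to compound 4 (the limit leaves the size open), none beyond the scatter. Compound 4 is expected to sit near 50000 nM, within 20000 nM to 100000 nM, most probably again reported only as a limit.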

Compound 4, half-maximal cytotoxic concentration: "not toxic" (no number reported)
No number was reported for compound 4, so the estimate cannot be set against anything.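

For the compounds shown here, compound 3 and compound 4 yield no new step: compound 4 carries no number, and the entry for compound 3 is only a limit. The compounds shown leave open what concentration of any of them would be cytotoxic in this assay and whether exchanging ethyl for chloro changes that concentration at all.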